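The compounds below may be only part of what the source reports. "The series", "measured", "known", "first", "only" and "open" are said of these compounds alone.

Three amides sharing one core have been tested in a functional assay on CLL cells (Homo sapiens) for cytotoxicity, read by MTT assay, with a stated time of 48 h; a lower number here means that less compound is needed, a higher number that more compound is needed for the effect. Compound 1 `C=C(CC)C(=O)c1ccc(OCC(=O)NCC(=O)O)c(Cl)c1Cl` reaches only a limit, > 25000 nM. Compound 2 `C=C(CC)C(=O)c1ccc(OCC(=O)NCCCN2CCCC2=O)c(Cl)c1Cl` gives 13800 nM, and compound 3 `C=C(CC)C(=O)c1ccc(OCC(=O)Nc2cccc(C(=O)O)c2)c(Cl)c1Cl` gives 20600 nM. For the measured compounds named here, compound 3 therefore lies within the scatter of compound 2, the only other exact number.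

Compound 4 `C=C(CC)C(=O)c1ccc(OCC(=O)NC(CS)C(=O)OCC)c(Cl)c1Cl` has 1-(ethoxycarbonyl)-2-sulfanylethyl in place of 3-carboxyphenyl on an amide-type nitrogen. The measured steps that bear on this change also swap the group on that nitrogen. They are an at least 1.8-fold lower number from compound 1 to compound 2 (0.25 log units; that floor lies within the scatter), an at least 1.2-fold lower number from compound 1 to compound 3 (0.08 log units; that floor lies within the scatter) and a 1.5-fold higher number from compound 2 to compound 3 (0.17 log units; within the scatter). None of them is shown to pass the scatter, so they offer no precedent for a large change. Compound 4 shares with compound 2, at 13800 nM, the lack of a free carboxy group, which tips the expectation slightly towards a lower number in this assay. The expected change is small, a 1.7-fold lower number from compound 3 to compound 4 (0.23 log units; within the scatter), and may not clear the scatter. The estimated value for compound 4 is 12000 nM, with an expected range from 4000 nM to 25000 nM.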

Compound 4, half-maximal effective concentration: 4800 nM
Compound 4: middle estimate off by 2.5-fold (0.40 log units), on the high side, and the stated range covers the measured number.
By their numbers in this assay, from the lowest: compound 4; then compounds 2 and 3 (each within the scatter of the next). At a limit, above all of these: compound 1.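

In this assay the group on an amide-type nitrogen now gives steps that pass the scatter, which no earlier step there was shown to do, with a 4.3-fold lower number from compound 3 to compound 4 (0.63 log units; beyond the scatter) and a 2.9-fold lower number from compound 2 to compound 4 (0.46 log units; beyond the scatter) as the new steps. Compound 2 also carries no carboxy group, so the absence of that group alone does not match the lower number of compound 4. Compound 1 gives only a limit, so an at least 5.2-fold lower number from compound 1 to compound 4 (0.71 log units; beyond the scatter) is read as a floor: the limit of > 25000 nM in this assay, at which 1 of the 4 values shown sits.

The entering 1-(ethoxycarbonyl)-2-sulfanylethyl brings in a sulfanyl and an ethyl ester together, so the compounds shown leave open which part goes with the lower number. A carboxylic acid in place of the ethyl ester, or a hydroxyl in place of the sulfanyl, would separate the two.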